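A few compounds are considered here, and "the series" means these few. Any claim that something is new, unique, unknown or untested is made for them only; others in the source may bear on it.

The measured compounds:
compound 1, `Cc1cn([C@@H]2O[C@H](CO[Si](C)(C)C(C)(C)C)[C@@]3(OS(=O)(=O)C=C3NC(N)=O)[C@H]2O[Si](C)(C)C(C)(C)C)c(=O)n(C)c1=O`, with 16000 nM in an ADME assay on HEL cells (Homo sapiens) for cytotoxicity, with a stated time of 3 days; a higher number here means that more compound is tolerated, a lower number that less compound is tolerated;
compound 2, `CCNC(=O)NC1=CS(=O)(=O)O[C@@]12[C@@H](CO[Si](C)(C)C(C)(C)C)O[C@@H](n1cc(C)c(=O)n(C)c1=O)[C@@H]2O[Si](C)(C)C(C)(C)C`, with >= 3200 nM in this assay;
compound 3, `CCOC(=O)NC(=O)NC1=CS(=O)(=O)O[C@@]12[C@@H](CO[Si](C)(C)C(C)(C)C)O[C@@H](n1cc(C)c(=O)n(C)c1=O)[C@@H]2O[Si](C)(C)C(C)(C)C`, with 10000 nM in this assay.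

The value of compound 2 is a limit of this assay and not a number, as one of the three values sits there (the limit of >= 3200 nM in this assay, at which 1 of the 3 values shown sits). Among the two actual numbers, compound 3 gives the lowest one; its nearest neighbour is compound 1, and the step of a 1.6-fold lower number from compound 1 to compound 3 (0.20 log units; within the scatter) stays within the scatter. The steps a step that the limit leaves unreadable from compound 1 to compound 2 and a step that the limit leaves unreadable from compound 2 to compound 3 give no readable size.

Compound 4, `CCOC(=O)CNC(=O)NC1=CS(=O)(=O)O[C@@]12[C@@H](CO[Si](C)(C)C(C)(C)C)O[C@@H](n1cc(C)c(=O)n(C)c1=O)[C@@H]2O[Si](C)(C)C(C)(C)C`, differs from compound 3 in one place: (ethoxycarbonyl)methyl in place of ethoxycarbonyl on an amide-type nitrogen. Within the data shown here, the only step that bears on it is the one that put an ethoxycarbonyl on the same amide-type nitrogen, a 1.6-fold lower number from compound 1 to compound 3 (0.20 log units; within the scatter), which did not move the number beyond the scatter; the other two steps are unreadable. Compound 4 is therefore expected to behave much like compound 3, and the expected step of a 1.2-fold higher number from compound 3 to compound 4 (0.08 log units; within the scatter) amounts to nothing beyond the scatter. Compound 4 is estimated at 12000 nM in this assay, with a range from 5000 nM to 30000 nM.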

Compound 4, minimum cytotoxic concentration: 16000 nM
Estimate against measurement, compound 4: 1.3-fold (0.12 log units) below; measured number inside the range.
By their numbers in this assay, from the lowest: compounds 3, 1 and 4 (each within the scatter of the next).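

In this assay, (ethoxycarbonyl)methyl in place of ethoxycarbonyl on the amide-type nitrogen gives a 1.6-fold higher number from compound 3 to compound 4 (0.20 log units; within the scatter), and the same group in place of the hydrogen on that nitrogen gives no change at the digits printed from compound 1 to compound 4 (within the scatter). The earlier compounds had shown only ethoxycarbonyl with a readable step at this position; now two different groups there, one of them set on a saturated chain carbon, leave compound 1, compound 3 and compound 4 all within the scatter of one another. Among these compounds, the value of compound 2 is a limit and not a number, so no step to or from compound 2 can be read, including the one to compound 4, which replaces methyl with ethoxycarbonyl on the saturated chain carbon: the limit of >= 3200 nM in this assay, at which 1 of the 4 values shown sits.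

The compounds shown therefore leave open whether ethyl on this nitrogen also belongs with the other three. They also leave open whether this tolerance would hold for a carboxylic acid in place of the ethyl ester end of the group, for an amine, or for a longer chain on the same nitrogen.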